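The source may hold more compounds than are shown below. What is called first, only, known or untested is meant among the compounds shown, and "the series" means these compounds.

Measured in a functional assay on PC-3 cells (Homo sapiens) for antiproliferative activity, read by MTT assay, with a stated time of 96 h; on this read-out lower numbers stand for stronger inhibition and higher numbers for weaker inhibition:
- compound 1 `CCN1CCN(c2ccc3nnnc(Nc4cccc(OC(F)(F)F)c4)c3n2)CC1`: 16900 nM
- compound 2 `FC(F)(F)Oc1cccc(Nc2nnnc3ccc(N4CCCC4)nc23)c1`: > 100000 nM, a limit and not a number
- compound 3 `FC(F)(F)Oc1cccc(Nc2nnnc3ccc(N4CCC(N5CCCCC5)CC4)nc23)c1`: 5580 nM

Compound 2 stands at the limit of > 100000 nM in this assay, at which 1 of the 3 values shown sits. Compound 4 `CC(C)N1CCN(c2ccc3nnnc(Nc4cccc(OC(F)(F)F)c4)c3n2)CC1` has 4-isopropylpiperazin-1-yl in place of pyrrolidin-1-yl on an aromatic carbon. For the measured compounds named here, the one measured step that bears on this is an at least 5.9-fold higher number from compound 1 to compound 2 (0.77 log units; beyond the scatter), with pyrrolidin-1-yl in place of 4-ethylpiperazin-1-yl. Compound 4 is therefore expected to reverse that step, with a change of similar size towards lower numbers in this assay. The expected change is an at least 6.6-fold lower number from compound 2 to compound 4 (0.82 log units; beyond the scatter). For compound 4 the estimate is 15000 nM, with an expected range of 5000 nM to 50000 nM.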

Compound 4, half-maximal inhibitory concentration: 13800 nM
The estimate for compound 4 lay 1.1-fold (0.04 log units) above the measured number; measured number inside the range.
By their numbers in this assay, from the lowest: compound 3; then compounds 4 and 1 (each within the scatter of the next). At a limit, above all of these: compound 2.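

In this assay, a second piperazine now stands with compound 1: the change to 4-isopropylpiperazin-1-yl gives an at least 7.2-fold lower number from compound 2 to compound 4 (0.86 log units; beyond the scatter), so the gain over pyrrolidin-1-yl does not rest on 4-ethylpiperazin-1-yl alone. Compound 2 remains a limit and not a number: the limit of > 100000 nM in this assay, at which 1 of the 4 values shown sits. Adding a methyl to the ethyl group gives a 1.2-fold lower number from compound 1 to compound 4 (0.09 log units; within the scatter), so the ethyl and isopropyl piperazines read alike.

From the compounds shown here alone, it remains open whether a morpholine or an unsubstituted piperazine at this position would read like compound 4 or like compound 2.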